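The compounds below may be only part of what the source reports. "The series", "measured", "known", "first", "only" and "open" are said of these compounds alone.

Among the compounds with values here, the three compounds measured so far share a fused core. Compound 1 `CSc1nnc(-c2ccccc2)c2cncn12` carries a phenyl and a methylsulfanyl group. In a functional assay for inhibition, with Homo sapiens as the target (on this read-out lower numbers stand for stronger inhibition and higher numbers for weaker inhibition), compound 1 gives > 48000 nM, which is a limit of the assay and not a number. Compound 2 `CCCc1nnc(SC)n2c(CCC)nc(C)c12` in this assay gives > 48000 nM, again a limit. Compound 3 `CCCc1nc(C)c2c(C)nnc(SC)n12` in this assay gives > 48000 nM, also a limit. Within the data shown here, the only step between measured compounds, a step that the two limits leave unreadable from compound 2 to compound 3, cannot be read because of the limit of > 48000 nM in this assay, at which 3 of the 3 values shown sit. Compound 3 therefore stands where every measured compound stands: at the limit, with no number to compare against.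

Compound 4 `CCCc1nc(C)c2c(-c3ccccc3)nnc(SC)n12` differs from compound 3 in one place: phenyl in place of methyl on an aromatic carbon. Among the measured compounds shown here, no measured step bears directly on this change; the one measured step was unreadable, and all three values sit at the same limit. The nearest hint is that compound 1, which also carries a phenyl on its core, in this assay gives > 48000 nM, a limit. In this assay the expected step is a step that the limit leaves unreadable from compound 3 to compound 4, nothing beyond the scatter. Compound 4 is expected to give 100000 nM, within 30000 nM to 400000 nM, most likely reported again only as a limit.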

Compound 4, half-maximal inhibitory concentration: > 48000 nM
Compound 4 ended at the assay's limit; the forecaster's own chance of this, stated with the estimate: 85%; the middle value is on the limit's open side.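

The steps from compound 2 and from compound 3 to compound 4 cannot be read, because at both ends of each step stands a limit of the assay and not a number: the limit of > 48000 nM in this assay, at which 4 of the 4 values shown sit.

The compounds shown leave open whether in this assay any change on the shared core would give a value that can be read as a number.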